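The source may hold more compounds than are shown below. What is called first, only, known or untested is meant among the compounds shown, and "the series" means these compounds.

Three compounds built on a shared core have been examined in an ADME assay on C8166 cells (Homo sapiens) for cytotoxicity, read by MTT assay; a lower number here means that less compound is tolerated, a higher number that more compound is tolerated. Compound 3 `Cc1cc(S(N)(=O)=O)ccc1NC(=O)COc1ccc(Cl)cc1C(O)c1cccc(F)c1` gives 37600 nM. Compound 1 `Cc1ccc(C(O)c2cc(Cl)ccc2OCC(=O)Nc2ccc(S(N)(=O)=O)cc2C)cc1` gives 38700 nM, and compound 2 `Cc1cc(S(N)(=O)=O)ccc1NC(=O)COc1ccc(Cl)cc1C(O)c1ccccc1Cl` gives 32000 nM. The number for compound 3 thus stands second highest of the three, nearest to that of compound 1 and furthest from that of compound 2, yet every gap among them lies within the scatter.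

Compound 4 `Cc1cc(S(N)(=O)=O)ccc1NC(=O)COc1ccc(Cl)cc1C(O)c1cc(Cl)cc(Br)c1` differs from compound 3 in one place: 3-bromo-5-chlorophenyl in place of 3-fluorophenyl on a saturated chain carbon bound to an aromatic carbon and an oxygen on a saturated carbon. All three measured steps vary the same group at the same place, and each was small: a 1.2-fold lower number from compound 1 to compound 2 (0.08 log units; within the scatter), a 1.0-fold lower number from compound 1 to compound 3 (0.01 log units; within the scatter) and a 1.2-fold higher number from compound 2 to compound 3 (0.07 log units; within the scatter). Because each of those steps lies within the scatter, the replacement leading to compound 4 is expected to leave the number essentially where it is, and the expected step is a 1.3-fold lower number from compound 3 to compound 4 (0.10 log units; within the scatter). Compound 4 is therefore estimated at 30000 nM, with a range from 15000 nM to 60000 nM.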

Compound 4, half-maximal cytotoxic concentration: 22900 nM
For compound 4 the middle estimate is 1.3-fold (0.12 log units) above the measured one, within the range that was stated.
By their numbers in this assay, from the lowest: compounds 4, 2, 3 and 1 (each within the scatter of the next).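

Of the four compounds, only compound 4 carries two halogens on the ring at this place, a bromine and a chlorine, and in this assay the change stays within the scatter of every other compound: a 1.6-fold lower number from compound 3 to compound 4 (0.22 log units; within the scatter), a 1.4-fold lower number from compound 2 to compound 4 (0.15 log units; within the scatter) and a 1.7-fold lower number from compound 1 to compound 4 (0.23 log units; within the scatter). On the saturated chain carbon bound to an aromatic carbon and an oxygen on a saturated carbon, 3-bromo-5-chlorophenyl therefore reads the same as 3-fluorophenyl, 2-chlorophenyl and 4-methylphenyl, and no compound shown goes against this.

Going by these compounds, all four groups are six-membered aromatic rings of carbon only, so what a pyridine ring, a cyclohexyl group or an amine would do at this place remains open. Nothing available bears on what lies behind these small differences.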